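Aryl Amide Variation on a Triazolylthio Naphthol Core

The source may hold more compounds than are shown below. What is called first, only, known or untested is meant among the compounds shown, and "the series" means these compounds.

Measured compounds:
compound 1 `COc1ccc(C(=O)Nc2cc(Sc3ncn[nH]3)c(O)c3ccccc23)cc1` 30.8%
compound 2 `O=C(Nc1cc(Sc2ncn[nH]2)c(O)c2ccccc12)c1ccc(Cl)cc1` 50.1%

Compound 2 stands highest of the two numbers in an assay on isolated protein for inhibition of RAC-alpha serine/threonine-protein kinase (Homo sapiens), read by fluorescence, with a stated time of 30 min, tested at 10 uM; a lower number here means less inhibition, a higher number more inhibition at the concentration tested (going by the name of the read-out); its nearest neighbour is compound 1, whose value in this assay lies lower by the step of a number 19.3 percentage points higher from compound 1 to compound 2 (beyond the scatter). Compound 3 `COc1cccc(C(=O)Nc2cc(Sc3ncn[nH]3)c(O)c3ccccc23)c1` has not been measured. It differs from compound 2 by 3-methoxyphenyl in place of 4-chlorophenyl on a carbonyl carbon. Among the measured compounds shown here, only one measured step bears on this change, a number 19.3 percentage points higher from compound 1 to compound 2 (beyond the scatter), in which chloro in place of methoxy raised inhibition modestly. For the measured compounds named here, compound 3 reverses that exchange of a chlorine for a methoxy, but with the methoxy placed differently on the ring, so no measured pair tests the exact change. Compound 3 is therefore expected to fall back toward compound 1, with the step of a number 15.1 percentage points lower from compound 2 to compound 3 (beyond the scatter) estimated in the downward direction. The value of compound 3 in this assay is estimated at 35%, within a range from 15% to 55%.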

Compound 3, a percentage reported as inhibition, at one concentration (the size of the read-out at that concentration, not a potency): 19.4%
Compound 3: the middle estimate sits 15.6 percentage points above what was measured; low and high end bracket the measured number.
By their numbers in this assay, from the lowest: compound 3; then compound 1; then compound 2.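

In this assay, the change on the carbonyl carbon shows that the ring place of the methoxy matters as well as its presence: 3-methoxyphenyl in place of 4-methoxyphenyl gives a number 11.4 percentage points lower from compound 1 to compound 3 (beyond the scatter). The exchange of 4-chlorophenyl for 3-methoxyphenyl gives a larger change, a number 30.7 percentage points lower from compound 2 to compound 3 (beyond the scatter), so that among these three compounds the read-out depends on both the group and where it sits on the aryl ring. No measurement given here accounts for these differences.

The compounds shown leave open whether 3-chlorophenyl would show a similar fall relative to 4-chlorophenyl, which would tell whether this ring place lowers the number for chlorine as it does for methoxy. Going by these compounds, how an amine or a carboxylic acid on the aryl ring would read in this assay also remains open.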